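Swapping the para substituent on the sulfonyl aryl ring

A few compounds are considered here, and "the series" means these few. Any claim that something is new, unique, unknown or untested is made for them only; others in the source may bear on it.

Among the measured compounds shown here, compound 2 `O=C1/C(=C/c2cccc(F)c2)CN(S(=O)(=O)c2ccc(Cl)cc2)C/C1=C\c1cccc(F)c1` gives 7800 nM in a functional assay on SMMC-7721 cells (Homo sapiens) for cytotoxicity, read by MTT assay, with a stated time of 24 h (on this read-out lower numbers stand for stronger inhibition and higher numbers for weaker inhibition), the highest of the two numbers so far; its nearest neighbour, compound 1 `O=C1/C(=C/c2cccc(F)c2)CN(S(=O)(=O)c2ccc(C(F)(F)F)cc2)C/C1=C\c1cccc(F)c1`, gives 4200 nM. Compound 3 `N#Cc1ccc(S(=O)(=O)N2C/C(=C\c3cccc(F)c3)C(=O)/C(=C/c3cccc(F)c3)C2)cc1` differs from compound 2 by cyano in place of chloro on an aromatic carbon. For the measured compounds named here, the only measured step at this position, a 1.9-fold higher number from compound 1 to compound 2 (0.27 log units; within the scatter), stayed within the scatter, and no step with a cyano group has been measured, so for compound 3 in this assay a change no larger than the scatter is expected, in either direction. Compound 3 is therefore estimated at 7000 nM, with a range of 2500 nM to 20000 nM, an expected step of a 1.1-fold lower number from compound 2 to compound 3 (0.05 log units; within the scatter).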

Compound 3, half-maximal inhibitory concentration: 4500 nM
Compound 3: the middle estimate sits 1.6-fold (0.19 log units) above what was measured; low and high end bracket the measured number.
By their numbers in this assay, from the lowest: compounds 1, 3 and 2 (each within the scatter of the next).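

In this assay, among the compounds shown here, the first step with a cyano group reads a 1.7-fold lower number from compound 2 to compound 3 (0.24 log units; within the scatter) and a 1.1-fold higher number from compound 1 to compound 3 (0.03 log units; within the scatter), so all three measured groups at this place on the aromatic ring now lie within the scatter of one another. Cyano, with its triple bond and hydrogen-bond acceptor, is not told apart from chloro or trifluoromethyl by this read-out. Nothing available gives a reason for these values. On these data alone, whether an amine or a carboxylic acid on this carbon would give a step beyond the scatter remains open, as does the effect of changes elsewhere on the shared core.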